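The source may report more compounds than this note shows. Statements on the series, on what has been measured and on what is new or still open speak of the compounds shown alone.

Measured in a functional assay on MCF7 cells (Homo sapiens) for inhibition, read by fluorescence, with a stated time of 72 h; on this read-out lower numbers stand for stronger inhibition of growth and higher numbers for weaker inhibition of growth:
compound 1 `CCCCCc1cc2nn(-c3ccccc3)cc2cn1` gives 11800 nM
compound 2 `Cc1nc(-c2ccccc2)cc2nn(-c3ccccc3)cc12` gives 11000 nM
compound 3 `c1ccc(-n2cc3cnccc3n2)cc1` gives > 100000 nM

Compound 3 stands at the edge of what this assay reports: its value is a limit of the assay and not a number, as the limit of > 100000 nM in this assay, at which 1 of the 3 values shown sits, records. Compound 4 `c1ccc(-c2cc3nn(-c4ccccc4)cc3cn2)cc1` differs from compound 3 by phenyl in place of hydrogen on an aromatic carbon. Within the data shown here, only one measured step bears directly on this change, and it runs the other way at the same carbon: an at least 8.4-fold higher number from compound 1 to compound 3 (0.92 log units; beyond the scatter), so taking the pentyl off weakened inhibition by at least a modest amount. Compound 2 also carries a phenyl on its core, alongside a methyl, and in this assay compound 2 gives 11000 nM, close to where compound 1 sits. Putting a phenyl onto the bare core of compound 3 is therefore expected to pull the number back down, with compound 4 expected to show a step of an at least 8.3-fold lower number from compound 3 to compound 4 (0.92 log units; beyond the scatter). Compound 4 is estimated at 12000 nM, with a range from 4000 nM to 45000 nM.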

Compound 4, concentration for 50% growth inhibition: 4800 nM
Compound 4: the middle estimate sits 2.5-fold (0.40 log units) above what was measured, within the range that was stated.
By their numbers in this assay, from the lowest: compound 4; then compounds 2 and 1 (each within the scatter of the next). At a limit, above all of these: compound 3.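

In this assay, among these compounds, phenyl on this aromatic carbon, next to the ring nitrogen, does more than restore inhibition of growth: phenyl in place of pentyl gives a 2.5-fold lower number from compound 1 to compound 4 (0.39 log units; beyond the scatter), so the ring outperforms the chain at this position, a difference the earlier compounds could not show. The methyl of compound 2 does not help either, since hydrogen in its place gives a 2.3-fold lower number from compound 2 to compound 4 (0.36 log units; beyond the scatter), and phenyl alone thus accounts for an at least 20-fold lower number from compound 3 to compound 4 (1.31 log units; beyond the scatter). That last step has an open end, as the value of compound 3 is a limit of the assay and not a number: the limit of > 100000 nM in this assay, at which 1 of the 4 values shown sits.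

The compounds shown leave open how an amine or a methoxy group on the phenyl of this carbon would read. Going by these compounds, how a cyclohexyl group would compare with phenyl at this position also stays open.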